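Cyclopropyl replacing 4-fluorophenyl on a five-membered aromatic ring

A few compounds are considered here, and "the series" means these few. Any claim that something is new, unique, unknown or untested is made for them only; others in the source may bear on it.

The series is followed in an assay on HEK293 cells for activation of Kir3.1/Kir3.2 (Homo sapiens), read by thallium flux; a higher number here means that more compound is needed for the effect, a lower number that less compound is needed. Compound 1 `Cc1cc(NC(=O)Cn2nnc(-c3ccccc3)n2)n(-c2ccccc2)n1` gives 3020 nM. Compound 2 `Cc1cc(NC(=O)Cn2nnc(-c3ccc(F)cc3)n2)n(C2CCCCC2)n1` gives 180 nM, the lowest of the two numbers measured; its nearest neighbour is compound 1, whose number is higher by a gap beyond the usual scatter. Compound 3 `Cc1cc(NC(=O)Cn2nnc(C3CC3)n2)n(C2CCCCC2)n1` is not yet measured and differs from compound 2 in one place: cyclopropyl in place of 4-fluorophenyl on an aromatic carbon. Going by the values given here, only two compounds are measured, and none of them differ in this single place, so there is no measured step to lean on. The change is nonetheless a sizable one, a six-membered aromatic ring of carbon only with a fluorine giving way to a three-membered non-aromatic ring of carbon only, and a step beyond the scatter toward a higher number is expected in this assay from compound 2 to compound 3, namely an 8.3-fold higher number from compound 2 to compound 3 (0.92 log units; beyond the scatter). For compound 3 the estimate in this assay is 1500 nM, within a range from 400 nM to 6000 nM.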

Compound 3, half-maximal effective concentration: > 3000 nM
Compound 3 ended at the assay's limit; the forecaster's own chance of this, stated with the estimate: 10%; at least 2.0-fold (0.30 log units) between middle value and limit.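

Cyclopropyl in place of 4-fluorophenyl on the aromatic carbon gives an at least 16-fold higher number from compound 2 to compound 3 (1.22 log units; beyond the scatter) in this assay and is the first change in the series confined to a single place. It shows that this carbon of the five-membered aromatic ring with 4 nitrogen does not tolerate every ring it carries, and that a three-membered non-aromatic ring here reads far worse than the 4-fluorophenyl of compound 2. The value of compound 3, > 3000 nM, is a limit and not a number, so the step gives only a minimum size: the limit of > 3000 nM in this assay, at which 1 of the 3 values shown sits.

The compounds shown leave open whether the fluorine or the six-membered aromatic ring carries the difference. As far as these compounds go, how a plain phenyl, a pyridine ring or a tert-butyl group would read on this carbon, with the rest of compound 2 kept, also remains open.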